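The source may report more compounds than this note shows. Statements on the series, on what has been measured and on what is new or still open speak of the compounds shown alone.

Measured compounds:
compound 1, `O=C(NCc1cccc(Cl)c1)c1ccc2cn(CCN3CCOC3=O)nc2c1`, 62 nm/s
compound 2, `CCCN(CC1CCOC1)C(=O)c1cc(OC)c2oc(NCc3cccc(Cl)c3)nc2c1`, 246 nm/s
compound 3, `COc1cc(C(=O)N2CCCC2)cc2nc(NCc3cccc(Cl)c3)oc12`, "not determined" (no result reported)

In an ADME assay on Caco-2 cells (Homo sapiens) for permeability, read by LC-MS, in the apical to basolateral direction, with a stated time of 2 h (a higher number here means that the compound crosses the layer faster, a lower number that the compound crosses the layer more slowly), compound 1 gives 62 nm/s, and compound 2 gives 246 nm/s. In this assay compound 3 stands at "not determined" (no result reported), so it offers no starting point of its own. Compound 4, `COc1cc(C(=O)N2CCC(O)CC2)cc2nc(NCc3cccc(Cl)c3)oc12`, differs from compound 3 by 4-hydroxypiperidin-1-yl in place of pyrrolidin-1-yl on a carbonyl carbon. Among the compounds with values here, no measured pair carries this change, so no step can be read from the data. A downward step of modest size in this assay is expected, though one that stays within the usual scatter cannot be ruled out. Compound 4 is expected to give 120 nm/s, between 40 nm/s and 350 nm/s. The anchor for this expectation is the core shared with compound 3, carried by compound 2, which gives 246 nm/s.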

Compound 4, apparent permeability: 71 nm/s
Compound 4: middle estimate off by 1.7-fold (0.23 log units), on the high side, and the stated range covers the measured number.
By their numbers in this assay, from the lowest: compounds 1 and 4 (each within the scatter of the next); then compound 2.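

On the carbonyl carbon of the shared core, 4-hydroxypiperidin-1-yl in place of ((oxolan-3-yl)methyl)(propyl)amino gives a 3.5-fold lower number from compound 2 to compound 4 (0.54 log units; beyond the scatter) in this assay, so the number at this position does move with the amide group it carries. The step from pyrrolidin-1-yl to 4-hydroxypiperidin-1-yl cannot be read: compound 3 has no reported result. Nothing measured here accounts for the step. Open, on these data alone, is whether the step follows the hydroxyl group, the ring or the loss of the open-chain substituents. An unsubstituted piperidin-1-yl or a morpholin-4-yl on the same carbonyl carbon would help separate these.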